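The compounds below may be only part of what the source reports. "The series", "measured", "known", "first", "only" and "open" are said of these compounds alone.

Measured so far:
- compound 1 `CC(=O)c1ccc(OCCCOc2ccc3c(O)c([N+](=O)[O-])c(=O)oc3c2)cc1`: 6100 nM
- compound 2 `Cc1ccc(OCCCOc2ccc3c(O)c([N+](=O)[O-])c(=O)oc3c2)cc1`: 4500 nM

Both numbers come from a functional assay on ileum (Cavia porcellus) for antagonist activity; a lower number here means a stronger inhibitor, a higher number a weaker inhibitor. With only these two compounds measured, compound 2 gives 4500 nM and compound 1 gives 6100 nM. These values lie within the usual scatter of each other, so the two compounds cannot be ranked.

The next compound is compound 3 `Cc1ccc(OCCCOc2ccc3c(O)c([N+](=O)[O-])c(=O)oc3c2)c([N+](=O)[O-])c1`, which keeps all of compound 2 and adds one group: nitro in place of hydrogen on an aromatic carbon. In short, a 4-methylphenyl group becomes a 4-methyl-2-nitrophenyl group.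

Going by the values given here, only one measured step bears on this change, and only loosely. It is a 1.4-fold lower number from compound 1 to compound 2 (0.13 log units; within the scatter), where an acetyl group gives way to a methyl group. Among the compounds with values here, that step stays within the scatter, but it is a different change, and no measured compound carries this added nitro. The data therefore point in neither direction.

The expectation starts from compound 2 at 4500 nM and assumes no real shift, so the expected step is a 1.1-fold lower number from compound 2 to compound 3 (0.05 log units; within the scatter), within the scatter. For compound 3 the estimated value is 4000 nM, with an expected range from 1300 nM to 12000 nM.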

Compound 3, half-maximal inhibitory concentration: > 10000 nM
Compound 3 ended at the assay's limit (the forecaster's own chance of this, stated with the estimate: 5%); middle value at least 2.5-fold (0.39 log units) from the limit.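

Adding a nitro group on an aromatic carbon of the 4-methylphenyl ring, at the place ortho to a large group and meta to the methyl group, gives the first change in this series that clears the scatter in this assay: an at least 2.2-fold higher number from compound 2 to compound 3 (0.34 log units; beyond the scatter). Compound 3 gives > 10000 nM, which is a limit of the assay and not a number, so only the floor of this weakening is known, not its full size: the limit of > 10000 nM in this assay, at which 1 of the 3 values shown sits A second step, an at least 1.6-fold higher number from compound 1 to compound 3 (0.21 log units; that floor lies within the scatter), replaces 4-acetylphenyl with 4-methyl-2-nitrophenyl and so changes more than one place, and with its floor inside the scatter it cannot be read as a ranking.

Going by these compounds, it remains open whether the weakening belongs to the nitro group itself or would follow any group at this place, which a fluorine, a methoxy group or an amine there could separate. Also open, on these data alone, is whether the same nitro group would weaken the compounds when set elsewhere on the ring, or when joined to the core through a longer chain.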